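A few compounds are considered here, and "the series" means these few. Any claim that something is new, unique, unknown or untested is made for them only; others in the source may bear on it.

Going by the values given here, compound 2 `O=C(CCc1cccc2c1B(O)OC2)Nc1cccc(Br)c1` gives 20000 nM in an ADME assay on WI-38 cells (Homo sapiens) for cytotoxicity, read by MTT assay, with a stated time of 72 h (a lower number here means a stronger inhibitor, a higher number a weaker inhibitor), the second highest of the three numbers so far. Compound 1 `O=C(CCc1cccc2c1B(O)OC2)Nc1ccc(I)cc1` gives 49000 nM in this assay, and the step of a 2.5-fold lower number from compound 1 to compound 2 (0.39 log units; beyond the scatter) is the only one here beyond the scatter. Compound 3 `Cc1ccc(NC(=O)CCc2cccc3c2B(O)OC3)cc1Br` gives 15000 nM in this assay, the step of a 1.3-fold lower number from compound 2 to compound 3 (0.12 log units; within the scatter) lying within it. Compound 4 `COc1cc(OC)cc(-c2cccc(NC(=O)CCc3cccc4c3B(O)OC4)c2)c1` differs from compound 2 by 3,5-dimethoxyphenyl in place of bromo on an aromatic carbon. Both measured steps alter the group carried on the amide-type nitrogen and move the number at most modestly, so a step of modest size at most is expected in this assay, with no direction firmly indicated. Compound 4 is expected at 15000 nM, within 5000 nM to 45000 nM. That estimate means a step of a 1.3-fold lower number from compound 2 to compound 4 (0.12 log units; within the scatter), expected to stay near the scatter.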

Compound 4, half-maximal inhibitory concentration: 1700 nM
Beside the measured number, compound 4's estimate is 8.8-fold (0.95 log units) above it; measured number below the stated range.
By their numbers in this assay, from the lowest: compound 4; then compounds 3 and 2 (each within the scatter of the next); then compound 1.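

Going by these compounds alone, on the aromatic carbon that carries bromo in compound 2, 3,5-dimethoxyphenyl gives a 12-fold lower number from compound 2 to compound 4 (1.07 log units; beyond the scatter) in this assay, a large step where the earlier steps were modest or within the scatter. The number at this position therefore responds far more to an added aromatic ring than the earlier changes of halogen and methyl suggested. Nothing available accounts for the step. From the compounds shown here alone, whether the ring alone or its methoxy groups carry the step stays open. Also open, going by these compounds, is how plain phenyl, or an amine or carboxylic acid on that ring, would read here.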